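Orexin-1 binding: tetrazolyl replacing ethoxy on the benzamide

The source may report more compounds than this note shows. Statements on the series, on what has been measured and on what is new or still open speak of the compounds shown alone.

Compound 1 `Cc1c(C#N)ccnc1O[C@@H]1CC[C@@H](C)N(C(=O)c2ccccc2C(F)(F)F)C1` gives in an assay on cells for displacement of a labelled ligand from Orexin/Hypocretin receptor type 1 (Homo sapiens) (a higher number here means a weaker inhibitor, a lower number a stronger inhibitor), 1160 nM. Compound 2 `CCOc1ccccc1C(=O)N1C[C@H](Oc2nccc(C#N)c2C)CC[C@H]1C` gives in this assay 594 nM. Among the compounds with values here, the only step in this set is a 2.0-fold lower number from compound 1 to compound 2 (0.29 log units; within the scatter); compound 2 therefore stands next to compound 1 without being separated from it, and both numbers sit in the same region of this assay.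

Compound 3 `Cc1c(C#N)ccnc1O[C@@H]1CC[C@@H](C)N(C(=O)c2ccccc2-n2ncnn2)C1` is reached from compound 2 by the change (2H-tetrazol-2-yl in place of ethoxy on an aromatic carbon). Within the data shown here, the one measured step, a 2.0-fold lower number from compound 1 to compound 2 (0.29 log units; within the scatter), concerns the same aromatic carbon and exchanged two non-ring groups with a result inside the scatter; it is the only step that bears on the present change. Among the measured compounds shown here, no measured compound carries a five-membered aromatic ring at this position, so the step into the tetrazol-2-yl has no direct precedent here. On the evidence of the shown steps, a step of no more than the scatter is expected, with direction open.

The estimate for compound 3 in this assay is 400 nM, within 100 nM to 1600 nM, which corresponds to an expected step of a 1.5-fold lower number from compound 2 to compound 3 (0.17 log units; within the scatter).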

Compound 3, inhibition constant: 572 nM
Beside the measured number, compound 3's estimate is 1.4-fold (0.16 log units) below it; the range from low to high includes it.
By their numbers in this assay, from the lowest: compounds 3, 2 and 1 (each within the scatter of the next, the first and the last beyond it).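

In this assay, within the data shown here, 2H-tetrazol-2-yl is the first group at this aromatic carbon to bring a ring, and it gives a 1.0-fold lower number from compound 2 to compound 3 (0.02 log units; within the scatter) with 5 heavy atoms and 4 hydrogen-bond acceptors in place of the 3 heavy atoms and 1 hydrogen-bond acceptor of ethoxy, so this larger change in the substituent leaves the number inside the scatter. Among these compounds, measured against trifluoromethyl, the same ring gives a 2.0-fold lower number from compound 1 to compound 3 (0.31 log units; beyond the scatter), the only step in the set that is printed as beyond the scatter, and a modest one, while ethoxy remains within the scatter of both other groups. Nothing available on these compounds accounts for how closely the three groups read.

From the compounds shown here alone, whether an amine, a carboxylic acid or a longer alkoxy chain on this aromatic carbon would leave the same narrow region remains open, as does the outcome for a 1H-tetrazol-1-yl or a five-membered aromatic ring with fewer hetero atoms. Also open, going by these compounds, is whether this tolerance holds when the rest of the core of compound 3 is changed.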